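Benzyl in Place of Hydrogen on Compound 2

The source may hold more compounds than are shown below. What is called first, only, known or untested is meant among the compounds shown, and "the series" means these compounds.

Compound 1: `Cc1c(C#Cc2ccc(CCC(=O)O)cc2)ccnc1Cl`, 135 nM
Compound 2: `O=C(O)CCc1ccc(C#Cc2ccnc(Cl)c2)cc1`, 295 nM
Compound 3: `O=C(O)CCc1ccc(C#Cc2ccnc(Cl)c2Cc2ccccc2)cc1`, not yet measured

In an in vitro functional assay on 1321-N1 cells for agonist activity at Free fatty acid receptor 1 (Homo sapiens), read by fluorescence, spectrophotometry and calcium flux (on this read-out higher numbers stand for an effect only at larger amounts of compound and lower numbers for an effect already at smaller amounts), compound 1 gives 135 nM and compound 2 gives 295 nM. Within the data shown here, compound 2 thus stands at the higher of the two numbers, its only neighbour being compound 1, and the step between them is a 2.2-fold higher number from compound 1 to compound 2 (0.34 log units; beyond the scatter), where a hydrogen replaced a methyl on the aromatic carbon.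

Compound 3 differs from compound 2 by benzyl in place of hydrogen on an aromatic carbon. Among the measured compounds shown here, the one measured step that bears on this place is a 2.2-fold higher number from compound 1 to compound 2 (0.34 log units; beyond the scatter); compound 3 now puts a group back onto the same carbon, so the step is expected to run the other way, toward a lower number, and to be of modest size, roughly a 2.7-fold lower number from compound 2 to compound 3 (0.43 log units; beyond the scatter). For the measured compounds named here, no measured step covers a benzyl there, so the range is kept wide. Compound 3 is therefore estimated at 110 nM, between 30 nM and 450 nM.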

Compound 3, half-maximal effective concentration: 794 nM
Beside the measured number, compound 3's estimate is 7.2-fold (0.86 log units) below it; the measured number lies above the stated range.
By their numbers in this assay, from the lowest: compound 1; then compound 2; then compound 3.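

At this aromatic carbon, ortho to a chloro group, a substituent does not by itself bring the number down in this assay: benzyl in place of hydrogen gives a 2.7-fold higher number from compound 2 to compound 3 (0.43 log units; beyond the scatter), the opposite direction to the change seen with methyl, a 2.2-fold higher number from compound 1 to compound 2 (0.34 log units; beyond the scatter). Phenyl in place of a hydrogen on that methyl gives a 5.9-fold higher number from compound 1 to compound 3 (0.77 log units; beyond the scatter), so the methyl and benzyl compounds lie on opposite sides of the compound carrying hydrogen here. No measurement is at hand that accounts for this reversal.

The three compounds leave open where the direction turns between methyl and benzyl, and how an ethyl group, a methoxy group or a phenyl ring set directly on this carbon would read. Also open, as far as these compounds go, is whether the same order holds with an amine in place of the chloro group.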